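The source may report more compounds than this note shows. Statements on the series, on what has been measured and on what is new or still open speak of the compounds shown alone.

Measured in an ADME assay on WI-38 cells (Homo sapiens) for cytotoxicity, read by MTT assay, with a stated time of 72 h; a higher number here means a weaker inhibitor, a lower number a stronger inhibitor:
compound 1 `CCNC(=O)CCc1cccc2c1B(O)OC2`: > 100000 nM (a limit)
compound 2 `O=C(CCc1cccc2c1B(O)OC2)NCc1ccccc1`: > 100000 nM (a limit)
compound 3 `O=C(CCc1cccc2c1B(O)OC2)Nc1ccc(Br)cc1`: 42000 nM

Compound 3 carries the only number in this set, and the other two values are limits, as shown by the limit of > 100000 nM in this assay, at which 2 of the 3 values shown sit. Compound 4 `CC(C)(C)OC(=O)NCc1ccc(NC(=O)CCc2cccc3c2B(O)OC3)cc1` has ((tert-butoxycarbonyl)amino)methyl in place of bromo on an aromatic carbon, para to a large group: ((tert-butoxycarbonyl)amino)methyl in place of bromo on an aromatic carbon.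

Going by the values given here, no measured step changes the bromo itself, so the size of this change is not measured directly. The nearest evidence lies at the amide-type nitrogen. The step that the two limits leave unreadable from compound 1 to compound 2 cannot be read. The steps of an at least 2.3-fold lower number from compound 1 to compound 3 (0.37 log units; beyond the scatter) and an at least 2.3-fold lower number from compound 2 to compound 3 (0.37 log units; beyond the scatter) both introduce 4-bromophenyl and are both beyond the scatter, but their full size is hidden by the limits.

Compound 4 keeps the aromatic ring on that nitrogen, so only a small rise in this assay is expected, without a clear step beyond the scatter. The expected change is a 1.3-fold higher number from compound 3 to compound 4 (0.12 log units; within the scatter). For compound 4 the estimated value is 55000 nM, with an expected range of 22000 nM to 100000 nM.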

Compound 4, half-maximal inhibitory concentration: 4800 nM
Beside the measured number, compound 4's estimate is 11-fold (1.06 log units) above it, and the stated range ends above it.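

In this assay, the group on an aromatic carbon, para to a large group, moves the number with the rest of the molecule unchanged: ((tert-butoxycarbonyl)amino)methyl in place of bromo gives an 8.8-fold lower number from compound 3 to compound 4 (0.94 log units; beyond the scatter). The aromatic ring on the amide-type nitrogen is therefore not the only feature of the series that matters in this assay, since a change on that ring alone gives a step of this size. The earlier steps all changed the group on the amide-type nitrogen, and none of them can be read in full: the limit of > 100000 nM in this assay, at which 2 of the 4 values shown sit.

Going by these compounds, it remains open whether the lower number goes with the whole ((tert-butoxycarbonyl)amino)methyl group or only with part of it, a question that a free aminomethyl amine, a carboxylic acid or a longer alkyl chain at this carbon would address. A single pair also leaves open whether the step carries over to other groups on the amide-type nitrogen.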